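Phenyl for vinyl: expected tolerance of compound 3

This account rests on a few compounds, and the source may have more. Where it says the series, first, only, none or still open, it means among the compounds named here.

Compound 2 `C=Cc1csc(CN[C@@H]2C[C@H]3C[C@@H]([C@H]2C)C3(C)C)c1` gives the lower of the two numbers in an ADME assay on MDCK cells (Canis lupus familiaris) for cytotoxicity, read by microscopy, with a stated time of 48 h (a lower number here means that less compound is tolerated, a higher number that more compound is tolerated), with 6250 nM. Its nearest neighbour, compound 1 `CCCCc1csc(CN[C@@H]2C[C@H]3C[C@@H]([C@H]2C)C3(C)C)c1`, gives 12500 nM, and the step of a 2.0-fold lower number from compound 1 to compound 2 (0.30 log units; within the scatter) is within the scatter. Compound 3 `C[C@H]1[C@H](NCc2cc(-c3ccccc3)cs2)C[C@H]2C[C@@H]1C2(C)C` differs from compound 2 by phenyl in place of vinyl on an aromatic carbon. For the measured compounds named here, the only measured step, vinyl in place of butyl on an aromatic carbon, bears on this change just loosely and was small, so no step beyond the scatter is expected in this assay. The expected step is no change at the digits printed from compound 2 to compound 3 (within the scatter). Compound 3 is therefore estimated at 6250 nM, within a range from 1560 nM to 25000 nM.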

Compound 3, minimum cytotoxic concentration: 5000 nM
Compound 3: the middle estimate sits 1.3-fold (0.10 log units) above what was measured; the range from low to high includes it.
By their numbers in this assay, from the lowest: compounds 3, 2 and 1 (each within the scatter of the next, the first and the last beyond it).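

In this assay phenyl in place of vinyl on this aromatic carbon, two ring bonds from the ring sulfur, gives a 1.3-fold lower number from compound 2 to compound 3 (0.10 log units; within the scatter) and so does not separate the two groups. Phenyl in place of butyl at the same place gives a 2.5-fold lower number from compound 1 to compound 3 (0.40 log units; beyond the scatter) as the only step in the set beyond the scatter, though a modest one. Nothing available accounts for either step. As far as these compounds go, whether an amine, a carboxylic acid or a longer chain at this position would move the tolerated concentration further stays open.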